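Swapping Chlorine for Fluorine on a Chalcone-Type Pyrazole

The compounds below may be only part of what the source reports. "The series", "measured", "known", "first", "only" and "open" are said of these compounds alone.

Of the compounds shown here, three sharing a core have been tested in a functional assay on CCRF-CEM cells (Homo sapiens) for inhibition, read by sulforhodamine B assay, with a stated time of 48 h; a higher number here means a weaker inhibitor of growth, a lower number a stronger inhibitor of growth. Compound 1 `COc1ccc(-c2cc(/C=C/C(=O)c3ccc(N)cc3)[nH]n2)cc1` gives 1320 nM. Compound 2 `COc1cc(-c2cc(/C=C/C(=O)c3ccc(Cl)c(Cl)c3)[nH]n2)cc(OC)c1OC` gives 2150 nM. Compound 3 `COc1ccc(C(=O)/C=C/c2cc(-c3cc(OC)c(OC)c(OC)c3)n[nH]2)cc1OC` gives 620 nM. Compound 2 stands at the highest of the three numbers: compound 1 lies within the scatter of it, while the step of a 3.5-fold lower number from compound 2 to compound 3 (0.54 log units; beyond the scatter) goes beyond the scatter, so compound 3 is the strongest inhibitor of growth among the three.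

The next compound, compound 4 `COc1cc(-c2cc(/C=C/C(=O)c3ccc(F)c(F)c3)[nH]n2)cc(OC)c1OC`, departs from compound 2 by a single change: 3,4-difluorophenyl in place of 3,4-dichlorophenyl on a carbonyl carbon. For the measured compounds named here, the one measured step that starts from compound 2, a 3.5-fold lower number from compound 2 to compound 3 (0.54 log units; beyond the scatter), replaced the 3,4-dichlorophenyl with a 3,4-dimethoxyphenyl, a different group from the one entering here, so it bears on the present change only loosely. Going by the values given here, no measured pair compares a 3,4-dichlorophenyl with a 3,4-difluorophenyl. The expectation is therefore a step of a 1.1-fold lower number from compound 2 to compound 4 (0.03 log units; within the scatter) that stays within the scatter, in either direction. Compound 4 is estimated at 2000 nM, within a range from 800 nM to 5000 nM.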

Compound 4, concentration for 50% growth inhibition: 3800 nM
Estimate against measurement, compound 4: 1.9-fold (0.28 log units) below; measured number inside the range.
By their numbers in this assay, from the lowest: compound 3; then compounds 1, 2 and 4 (each within the scatter of the next, the first and the last beyond it).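

In this assay, the 3,4-difluorophenyl in place of the 3,4-dichlorophenyl on the carbonyl carbon gives a 1.8-fold higher number from compound 2 to compound 4 (0.25 log units; within the scatter) and so does not set the two compounds apart: at this position, the two halogen-bearing rings cannot be told apart in this assay. The 3,4-dimethoxyphenyl does stand apart from both, since a 6.1-fold higher number from compound 3 to compound 4 (0.79 log units; beyond the scatter) is a larger step than a 3.5-fold lower number from compound 2 to compound 3 (0.54 log units; beyond the scatter) and both lie beyond the scatter, which shows that the group on the carbonyl carbon can matter even though this halogen exchange does not. Nothing available explains the gap between the methoxy-bearing ring and the two halogen-bearing rings.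

On these data alone, whether a ring with a single methoxy keeps the lower number of compound 3 remains open. So does the effect at this position of a ring bearing a nitrile or a carboxylic acid.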